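Swapping Trifluoromethyl for Phenoxy: An Expected Binding Number

The compounds below may be only part of what the source reports. "The series", "measured", "known", "first", "only" and "open" are said of these compounds alone.

Going by the values given here, compound 2 `FC(F)(F)c1ccnc(N2CCC(NC(=S)Nc3cccnc3)CC2)c1` was tested in an assay on membranes from brain for binding affinity to Lysophosphatidylserine lipase ABHD12 (Mus musculus), read by fluorescence, with a stated time of 20 min (on this read-out lower numbers stand for stronger inhibition and higher numbers for weaker inhibition), where compound 2 gives 640 nM, the highest of the three numbers known so far, although compound 1 sits within the scatter of it. Compound 1 `FC(F)(F)c1cc(Cl)nc(N2CCC(NC(=S)Nc3cccnc3)CC2)c1` gives 540 nM and compound 3 `FC(F)(F)c1ccnc(N2CCC(NC(=S)Nc3cccnc3)CC2)c1Cl` gives 300 nM. The known steps are a 1.2-fold higher number from compound 1 to compound 2 (0.07 log units; within the scatter) and a 2.1-fold lower number from compound 2 to compound 3 (0.33 log units; beyond the scatter). Compound 4 `S=C(Nc1cccnc1)NC1CCN(c2cc(Oc3ccccc3)ccn2)CC1` differs from compound 2 by phenoxy in place of trifluoromethyl on an aromatic carbon. Neither measured step concerns this exchange, since both swap chloro for hydrogen, and even the larger of them is only modest. No step beyond the scatter is therefore expected in either direction, and the estimated step is a 1.2-fold lower number from compound 2 to compound 4 (0.07 log units; within the scatter). Compound 4 is expected to give about 550 nM in this assay, within a range from 150 nM to 2000 nM.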

Compound 4, half-maximal inhibitory concentration: 1900 nM
Compound 4: middle estimate off by 3.5-fold (0.54 log units), on the low side, and the stated range covers the measured number.
By their numbers in this assay, from the lowest: compounds 3, 1 and 2 (each within the scatter of the next, the first and the last beyond it); then compound 4.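

At this carbon, opposite the ring nitrogen, the group matters: phenoxy in place of trifluoromethyl gives a 3.0-fold higher number from compound 2 to compound 4 (0.47 log units; beyond the scatter), which means weaker inhibition. The earlier steps exchanged only chloro and hydrogen, so this is the first change shown that puts a new aromatic ring on the core, and here it costs inhibition. Nothing measured here explains the loss. One pair cannot tell whether the ring or its oxygen matters more. From the compounds shown here alone, whether a methoxy group, a phenyl group or an amine at this carbon would restore inhibition remains open.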